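This account rests on a few compounds, and the source may have more. Where it says the series, first, only, none or still open, it means among the compounds named here.

Measured so far:
compound 1 `COc1cc(C)cc(-c2nn(CC#N)cc2-c2ccc(-c3cccc(C(C)=O)c3)nc2)c1`: 82%
compound 2 `Cc1cc(O)cc(-c2nn(CC#N)cc2-c2ccnc(-c3ccc(Oc4ccccc4)cc3)c2)c1`: 101%
compound 3 `COc1cc(C)cc(-c2nn(CC#N)cc2-c2ccnc(-c3ccc(N(C)C)cc3)c2)c1`: 16%

In a functional assay on HOP-62 cells (Homo sapiens) for cytotoxicity, read by sulforhodamine B assay, with a stated time of 48 h, tested at 100 nM (on this read-out higher numbers stand for a weaker effect at the one concentration tested and lower numbers for a stronger effect), compound 3 stands lowest of the three numbers, beyond the scatter from both others: compound 1 gives 82% and compound 2 gives 101%. Compound 4 `Cc1cc(O)cc(-c2nn(CC#N)cc2-c2ccnc(-c3ccc(N(C)C)cc3)c2)c1` has not been measured. It differs from compound 3 in one place: hydrogen in place of methyl on an oxygen on an aromatic ring, cut one bond further out, methoxy to hydroxy. Within the data shown here, no pair of measured compounds shows this change alone; compound 2 carries a hydroxy too, but differs from compound 3 elsewhere as well, so their values alone cannot be read as a step. The step of a number 19 percentage points higher from compound 3 to compound 4 (beyond the scatter) is expected to weaken the effect, moderately and beyond the scatter. Compound 4 is expected at 35%, within 10% to 80%.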

Compound 4, a percentage reported as activity, at one concentration (the size of the read-out at that concentration, not a potency): 80%
Compound 4: the middle estimate sits 45 percentage points below what was measured, and the stated range covers the measured number.
By their numbers in this assay, from the lowest: compound 3; then compounds 4 and 1 (each within the scatter of the next); then compound 2.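

In this assay, methoxy to hydroxy on the 3-methoxy-5-methylphenyl group can now be read as a single change, and the effect falls sharply, with a number 64 percentage points higher from compound 3 to compound 4 (beyond the scatter). With the hydroxy in place, the other aromatic substituent also matters, though less: dimethylamino in place of phenoxy gives a number 21 percentage points lower from compound 2 to compound 4 (beyond the scatter). Nothing measured here accounts for the loss of effect when the methyl leaves that oxygen. Going by these compounds, it remains open whether ethoxy, or an amine in place of the methoxy, would keep the effect of compound 3.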